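Chloro addition on the fluorophenyl amide of compound 2

This account rests on a few compounds, and the source may have more. Where it says the series, first, only, none or still open, it means among the compounds named here.

Measured so far:
- compound 1, `O=C(Nc1ccc(Oc2ccnc3[nH]ccc23)c(F)c1)c1nnn(-c2ccc(F)c(Cl)c2)c1C(F)(F)F`: 820 nM
- compound 2, `O=C(Nc1ccc(Oc2ccnc3[nH]ccc23)cc1)c1nnn(-c2ccc(F)cc2)c1C(F)(F)F`: 180 nM

In a functional assay on A549 cells (Homo sapiens) for cytotoxicity, read by MTT assay, with a stated time of 72 h (a higher number here means a weaker inhibitor, a lower number a stronger inhibitor), compound 2 gives 180 nM and stands as the lower of the two numbers recorded. Its nearest neighbour is compound 1, which in this assay gives 820 nM, a difference that lies beyond the scatter of repeated runs. Compound 1 differs from compound 2 in two places at once, so its value says nothing on its own about either change.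

Compound 3, `O=C(Nc1ccc(Oc2ccnc3[nH]ccc23)cc1)c1nnn(-c2ccc(F)c(Cl)c2)c1C(F)(F)F`, is not yet measured. Relative to compound 2 it carries chloro in place of hydrogen on an aromatic carbon, the same difference read one bond further out being 4-fluorophenyl to 3-chloro-4-fluorophenyl. Among the compounds with values here, no pair of measured compounds isolates this change. Within the data shown here, the only guidance is that compound 1, which also carries this chloro together with a further fluoro elsewhere, sits at the weaker end. A modest loss is therefore expected, but a result within the scatter of compound 2 cannot be excluded.

The estimated step of a 1.9-fold higher number from compound 2 to compound 3 (0.29 log units; within the scatter) is a small rise in the number. Compound 3 is expected to give 350 nM in this assay, within a range from 120 nM to 1000 nM.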

Compound 3, half-maximal inhibitory concentration: 1120 nM
Estimate against measurement, compound 3: 3.2-fold (0.51 log units) below, outside the stated range (above it).
By their numbers in this assay, from the lowest: compound 2; then compounds 1 and 3 (each within the scatter of the next).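

In this assay, within the data shown here, chloro in place of hydrogen on an aromatic carbon, ortho to a fluoro group, is now isolated for the first time: the change from 4-fluorophenyl to 3-chloro-4-fluorophenyl gives a 6.2-fold higher number from compound 2 to compound 3 (0.79 log units; beyond the scatter), a loss of activity beyond the scatter. The second single change, hydrogen in place of fluoro on an aromatic carbon, gives a 1.4-fold higher number from compound 1 to compound 3 (0.14 log units; within the scatter), which lies within the scatter, so with the chloro in place this exchange has no readable effect, and the chloro step alone is enough to cover the weak end of the series. Nothing available explains why the chloro lowers activity at this position.

From the compounds shown here alone, whether the loss is particular to chloro or follows any group placed here remains open, and a methyl, a methoxy or an amine at the same carbon would separate those readings. Going by these compounds, the fluoro exchange has also been read only with the chloro present, so its effect on the 4-fluorophenyl compound 2 is still unknown.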